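The source may hold more compounds than are shown below. What is called first, only, known or untested is meant among the compounds shown, and "the series" means these compounds.

Measured so far in an in vitro ADME assay on microsomes from liver (Homo sapiens) for metabolic stability; on this read-out lower numbers stand for slow clearance and higher numbers for fast clearance:

Compound 1 `COCc1nc2nc(C)cc(Nc3ccc(C(F)(F)F)cc3)n2n1` gives 6.7 mL.min-1.g-1.
Compound 2 `CCc1nc2nc(C)cc(Nc3ccc(C(F)(F)F)cc3)n2n1` gives < 5 mL.min-1.g-1, which is a limit of the assay and not a number (the limit of < 5 mL.min-1.g-1 in this assay, at which 1 of the 3 values shown sits).
Compound 3 `CCOc1nc2nc(C)cc(Nc3ccc(C(F)(F)F)cc3)n2n1` gives 7 mL.min-1.g-1.

Compound 3 stands among the two numerical values shown; its nearest neighbour is compound 1, and the step of a 1.0-fold higher number from compound 1 to compound 3 (0.02 log units; within the scatter) lies within the scatter. The step of an at least 1.4-fold higher number from compound 2 to compound 3 (0.14 log units; that floor lies within the scatter) is a floor only, and that floor lies within the scatter as well. Across the three compounds the shared core and the trifluoromethyl-bearing aniline are unchanged; only the small substituent on the five-membered ring varies, and none of these variations has produced a step beyond the scatter.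

Compound 4 `CSc1nc2nc(C)cc(Nc3ccc(C(F)(F)F)cc3)n2n1` is not yet measured. It differs from compound 3 as follows: methylsulfanyl in place of ethoxy on an aromatic carbon. Within the data shown here, the steps that bear on this change are a 1.0-fold higher number from compound 1 to compound 3 (0.02 log units; within the scatter) and an at least 1.4-fold higher number from compound 2 to compound 3 (0.14 log units; that floor lies within the scatter), both exchanging one small group for another at the same aromatic carbon, and both within the scatter. Among the measured compounds shown here, no measured step introduces sulfur. The expected step in this assay is therefore none beyond the scatter, no change at the digits printed from compound 3 to compound 4 (within the scatter). Compound 4 is estimated at 7 mL.min-1.g-1, with a range from 4 mL.min-1.g-1 to 13 mL.min-1.g-1.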

Compound 4, intrinsic clearance in microsomes in the Homo sapiens assay: 18.7 mL.min-1.g-1
For compound 4 the middle estimate is 2.7-fold (0.43 log units) below the measured one; measured number above the stated range.
By their numbers in the Homo sapiens assay, from the lowest: compounds 1 and 3 (each within the scatter of the next); then compound 4. At a limit, below all of these: compound 2.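

In the Homo sapiens assay this position had shown no step beyond the scatter among the small groups seen so far, yet methylsulfanyl opens one, with a 2.7-fold higher number from compound 3 to compound 4 (0.43 log units; beyond the scatter) against the ethoxy group and a 2.8-fold higher number from compound 1 to compound 4 (0.45 log units; beyond the scatter) against the methoxymethyl group, so the position does respond to what sits on it. In a physicochemical assay for lipophilicity, at pH 7.4 (a higher number here means a more lipophilic compound, a lower number a more polar compound), compound 3 gives 3.1 and compound 4 gives 3.2 and a number 0.10 log units higher from compound 3 to compound 4 (within the scatter) stays small in that read-out, so the step in clearance appears without a matching step beyond the scatter in distribution coefficient. In the Homo sapiens assay compound 2 stands at a limit and not at a number, so an at least 3.7-fold higher number from compound 2 to compound 4 (0.57 log units; beyond the scatter) is a floor only, though that floor is already beyond the scatter: the limit of < 5 mL.min-1.g-1 in the Homo sapiens assay, at which 1 of the 4 values shown sits.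

The change swaps ethoxy for methylsulfanyl and alters both the heteroatom and the chain, and the compounds shown cannot separate the two. Methoxy, which would keep the chain of methylsulfanyl with oxygen, and ethylsulfanyl, which would keep the chain of ethoxy with sulfur, are the pair that would tell these apart, and an amine at this carbon remains an open question as well.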